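This account rests on a few compounds, and the source may have more. Where it says the series, first, only, none or still open, it means among the compounds named here.

Working notes on the series. Compound 1 `COc1ccc(C2N=C(SCc3ccccc3Cl)NC(C)=C2C(=O)Nc2ccc(Br)cc2)cc1` and compound 2 `COc1ccc(C2N=C(SCc3cccc(Cl)c3)NC(C)=C2C(=O)Nc2ccc(Br)cc2)cc1` share one core; compound 3 `CC1=C(C(=O)Nc2ccc([N+](=O)[O-])cc2)C(c2ccc(Br)cc2)N=C(SCc2ccccc2Cl)N1` and compound 4 `CC1=C(C(=O)Nc2ccc([N+](=O)[O-])cc2)C(c2ccc(Br)cc2)N=C(SCc2cccc(Cl)c2)N1` share another. The difference between the two cores is not broken down here. In a functional assay on the whole organism (artery, strain albino) with Rattus norvegicus as the target, with a stated time of 180 min, at a dose of 10 mg/kg by the oral route (a lower number here means less inhibition, a higher number more inhibition at the dose given (going by the name of the read-out)), compound 1 gives 11.3%. In this assay compound 2 gives 27.3%. The change from compound 1 to compound 2 is 3-chlorophenyl in place of 2-chlorophenyl on a saturated chain carbon bound to a sulfur, and it made a number 16 percentage points higher from compound 1 to compound 2 (beyond the scatter). In this assay compound 3 gives 11.3%, the same value as compound 1 and within the scatter of it. Compound 4 is not yet measured. It differs from compound 3 by 3-chlorophenyl in place of 2-chlorophenyl on a saturated chain carbon bound to a sulfur, the same change as from compound 1 to compound 2, at the same place. Among the measured compounds shown here, with only one earlier instance of the change, the expectation for compound 4 rests on that one step. A step of about a number 15.7 percentage points higher from compound 3 to compound 4 (beyond the scatter) is expected from compound 3 to compound 4 in this assay, beside the earlier a number 16 percentage points higher from compound 1 to compound 2 (beyond the scatter) on the other core. Compound 4 is therefore expected to give about 27% in this assay, within 12% to 42%.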

Compound 4, a percentage reported as inhibition, in the whole organism at one dose (the size of the read-out at that dose, not a potency): 9.3%
Estimate against measurement, compound 4: 17.7 percentage points above; the whole stated range lies above it.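

On the core of compound 3, 3-chlorophenyl in place of 2-chlorophenyl on a saturated chain carbon bound to a sulfur made a number 2 percentage points lower from compound 3 to compound 4 (within the scatter) in this assay, so the change has no readable effect on this core. Set beside the earlier step, the change does not carry over from one core to the other in this assay: the same change on two cores in this assay, a number 16 percentage points higher (beyond the scatter) from compound 1 to compound 2 and a number 2 percentage points lower (within the scatter) from compound 3 to compound 4, 18 percentage points apart, beyond the scatter of two such steps

This rests on one pair per core and does not show which part of the difference between the two cores goes with the divergence, nor how the change would behave on any further core.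

The compounds shown carry only 2-chlorobenzyl and 3-chlorobenzyl on the sulfur, so it remains open how a plain benzyl, a longer chain or a chain ending in an amine would read at that place. Each compound is also shown at a single oral dose and time, which leaves open whether the two cores would keep this divergence at other doses.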